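A few compounds are considered here, and "the series" means these few. Any claim that something is new, unique, unknown or untested is made for them only; others in the source may bear on it.

Of the compounds shown here, three sharing one core have been measured in a functional assay on HEK293 cells for agonist activity at Free fatty acid receptor 1 (Homo sapiens), read by fluorescence and calcium flux, with a stated time of 10 min; on this read-out higher numbers stand for an effect only at larger amounts of compound and lower numbers for an effect already at smaller amounts. Compound 1 `O=C(O)CCc1ccc(NCC2COc3ccc(Cl)cc3O2)cc1F` gives 13600 nM. Compound 2 `CC#CC(CC(=O)O)c1ccc(OCC2COc3ccc(Cl)cc3O2)cc1` gives 100 nM, and compound 3 `Cn1ccnc1C(CC(=O)O)c1ccc(OCC2COc3ccc(Cl)cc3O2)cc1` gives 5880 nM. Among these three numbers compound 3 stands second highest: its nearest neighbour is compound 1, a little above it and beyond the scatter, while compound 2 lies far below it. For the measured compounds named here, the only step that changes a single place is a 59-fold higher number from compound 2 to compound 3 (1.77 log units; beyond the scatter), a large rise when the short chain group is replaced by the nitrogen-containing ring.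

Compound 4 `O=C(O)CC(c1ccc(F)cc1)c1ccc(OCC2COc3ccc(Cl)cc3O2)cc1` has not yet been measured. It differs from compound 3 by 4-fluorophenyl in place of 1-methyl-1H-imidazol-2-yl on a saturated chain carbon bound to an aromatic carbon and a saturated chain carbon. Going by the values given here, this is the same place that the one measured step touched, so that step is the only guide. Because a 59-fold higher number from compound 2 to compound 3 (1.77 log units; beyond the scatter) is large, this place clearly matters, and a substantial move is expected rather than one within the scatter. One step cannot show the direction on its own, but since a carbon-only ring, not a nitrogen-containing one, is entering, the number is expected to fall back toward compound 2. The expected step is a 39-fold lower number from compound 3 to compound 4 (1.59 log units; beyond the scatter). Compound 4 is therefore estimated at 150 nM, with a range from 40 nM to 600 nM.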

Compound 4, half-maximal effective concentration: 4310 nM
For compound 4 the middle estimate is 29-fold (1.46 log units) below the measured one; the whole stated range lies below it.
By their numbers in this assay, from the lowest: compound 2; then compounds 4 and 3 (each within the scatter of the next); then compound 1.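

In this assay, replacing the 1-methyl-1H-imidazol-2-yl group with 4-fluorophenyl leaves the number unchanged within the scatter (a 1.4-fold lower number from compound 3 to compound 4 (0.13 log units; within the scatter)), even though a ring of carbon only, carrying fluorine, enters in place of a five-membered ring with two nitrogens. The earlier step could not separate the effect of the nitrogen-containing ring from that of any ring, but here the two aromatic rings cannot be told apart, and both sit far from the prop-1-yn-1-yl group of compound 2 (a 43-fold higher number from compound 2 to compound 4 (1.63 log units; beyond the scatter)). So among these three compounds, the large difference at this place lies between the prop-1-yn-1-yl group and the two rings, not between the rings themselves, and nothing shown gives a reason for that difference.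

Going by these compounds, it remains open whether any ring on this chain carbon gives a number this high, or whether an unsubstituted phenyl, a pyridyl or a cyclopropyl would behave differently. On these data alone, it is also open whether the low number of compound 2 depends on the carbon-carbon triple bond itself, a question that a methyl, an ethyl or a prop-1-en-1-yl group at the same place could help to answer.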